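A few compounds are considered here, and "the series" means these few. Any claim that something is new, unique, unknown or untested is made for them only; others in the source may bear on it.

In a toxicity assay on MT4 cells (Homo sapiens) for cytotoxicity, read by MTT assay, with a stated time of 5 days (on this read-out higher numbers stand for lower toxicity in this test and lower numbers for higher toxicity in this test), compound 1 `Cc1cnc(Nc2ccc(C#N)cc2)nc1Nc1c(F)cc(-c2cccs2)cc1F` gives 8000 nM and compound 2 `Cc1cc(-c2ccco2)cc(C)c1Nc1ccnc(Nc2ccc(C#N)cc2)n1` gives 1700 nM, the lower of the two numbers by a gap beyond the usual scatter. Compound 3 `Cc1cc(-c2cncnc2)cc(C)c1Nc1ccnc(Nc2ccc(C#N)cc2)n1` carries pyrimidin-5-yl in place of furan-2-yl on an aromatic carbon. Among the measured compounds shown here, no measured pair shows this change, so any forecast is loose. For the measured compounds named here, the only other measured number, compound 1 at 8000 nM, sits higher, though that compound differs in more than this group. A moderate rise in this assay is expected, estimated as a 2.6-fold higher number from compound 2 to compound 3 (0.42 log units; beyond the scatter). The estimated value for compound 3 is 4500 nM, within a range of 1500 nM to 15000 nM.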

Compound 3, half-maximal cytotoxic concentration: 6800 nM
For compound 3 the middle estimate is 1.5-fold (0.18 log units) below the measured one; measured number inside the range.
By their numbers in this assay, from the lowest: compound 2; then compounds 3 and 1 (each within the scatter of the next).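

In this assay, among the compounds shown here, replacing furan-2-yl with pyrimidin-5-yl gives a 4.0-fold higher number from compound 2 to compound 3 (0.60 log units; beyond the scatter) and provides the only single-place comparison here. It shows that the group on this aromatic carbon can shift the number, with the higher number, meaning lower toxicity in this test, going to pyrimidin-5-yl. No measurement here explains why the number shifts.

On these data alone, whether a phenyl ring, a pyridine ring or an amine on this carbon would give a number closer to compound 2 or to compound 3 remains open. So does whether this replacement would give a similar step on another core.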